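This account rests on a few compounds, and the source may have more. Where it says the series, first, only, none or still open, it means among the compounds named here.

Of the compounds shown here, three have been measured in a functional assay on MDA-MB-231 cells (Homo sapiens) for inhibition, read by MTT assay, with a stated time of 48 h; a higher number here means a weaker inhibitor, a lower number a stronger inhibitor. Compound 1 `CN1CCN(c2ccc(Nc3ncc4c(n3)N(C3CCCC3)CC(=O)N4)cc2)CC1` gives 26100 nM in this assay. Compound 2 `O=C1CN(C2CCCC2)c2nc(Nc3ccc(N4CCCCC4)cc3)ncc2N1` differs from compound 1 by piperidin-1-yl in place of 4-methylpiperazin-1-yl on an aromatic carbon; in this assay compound 2 gives 25000 nM, so that a 1.0-fold lower number from compound 1 to compound 2 (0.02 log units; within the scatter). Compound 3 `CN1CCN(c2ccc(Nc3ncc4c(n3)N(C3CCCC3)CC(=O)N4C)nc2)CC1` is built on a different core, and how its core differs from that of compound 1 is not broken down here. In this assay compound 3 gives 23700 nM, and the three measured values all lie within the scatter of one another. Compound 4 `CN1C(=O)CN(C2CCCC2)c2nc(Nc3ccc(N4CCCCC4)cn3)ncc21` has not yet been measured. It differs from compound 3 by piperidin-1-yl in place of 4-methylpiperazin-1-yl on an aromatic carbon. This is the same kind of change as that from compound 1 to compound 2, though not the same: there the place was an aromatic carbon of a six-membered aromatic ring of carbon only, para to a large group, whereas here the ring holds 1 nitrogen and the carbon is two atoms from the ring nitrogen. The step from compound 3 to compound 4 in this assay is expected to be a 1.0-fold lower number from compound 3 to compound 4 (0.01 log units; within the scatter), resting on a 1.0-fold lower number from compound 1 to compound 2 (0.02 log units; within the scatter). Compound 4 is therefore estimated at 23000 nM, between 11000 nM and 48000 nM.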

Compound 4, half-maximal inhibitory concentration: 29300 nM
For compound 4 the middle estimate is 1.3-fold (0.11 log units) below the measured one, and the stated range covers the measured number.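

In this assay, putting piperidin-1-yl in place of 4-methylpiperazin-1-yl on the second core gives a 1.2-fold higher number from compound 3 to compound 4 (0.09 log units; within the scatter). Set beside the earlier step, this shows no difference between the two cores that could be told from the scatter: the same change on two cores in this assay, a 1.0-fold lower number (0.02 log units; within the scatter) from compound 1 to compound 2 and a 1.2-fold higher number (0.09 log units; within the scatter) from compound 3 to compound 4, 1.3-fold (0.11 log units) apart, within the scatter of two such steps. Across these two pairs the change thus carries over without a readable step, but two pairs cannot show that it would do so on other cores, and they cannot separate the core from the aromatic ring, which holds 1 nitrogen only in the second pair.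

The compounds shown leave open whether a different group at this place, such as morpholin-4-yl, an open-chain dimethylamino group or a carboxylic acid, would produce a step beyond the scatter. They also leave open whether the same change behaves alike in any setting other than this assay.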